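Furan-3-yl to phenyl on the shared core

A few compounds are considered here, and "the series" means these few. Any claim that something is new, unique, unknown or untested is made for them only; others in the source may bear on it.

Measured values in a functional assay on K562 cells (Homo sapiens), read by MTT assay, with a stated time of 72 h (a higher number here means a weaker inhibitor, a lower number a stronger inhibitor), are these:
- compound 1 `CSc1ncnc2c1c(-c1ccccc1)cn2[C@@H]1O[C@H](CO)[C@@H](O)[C@H]1O` gives > 20000 nM as a limit
- compound 2 `CNc1ncnc2c1c(-c1ccco1)cn2[C@@H]1O[C@H](CO)[C@@H](O)[C@H]1O` gives 15100 nM as a number
- compound 3 `CNc1ncnc2c1c(-c1ccoc1)cn2[C@@H]1O[C@H](CO)[C@@H](O)[C@H]1O` gives > 20000 nM as a limit

Compound 3 has no number, only the limit > 20000 nM in this assay as its result. The data crowd at the limit of > 20000 nM in this assay, at which 2 of the 3 values shown sit, and so leave little room to read a trend.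

The next step leads to compound 4 `CNc1ncnc2c1c(-c1ccccc1)cn2[C@@H]1O[C@H](CO)[C@@H](O)[C@H]1O` and places phenyl in place of furan-3-yl on an aromatic carbon of the shared core.

Among the measured compounds shown here, the one measured step at this carbon is an at least 1.3-fold higher number from compound 2 to compound 3 (0.12 log units; that floor lies within the scatter) and it gives no clear size to carry over. Compound 1 also carries a phenyl and shows > 20000 nM as a limit too. No step beyond the scatter is therefore expected in this assay and no direction can be named.

The expected size is a number no higher from compound 3 to compound 4 (the limit leaves the size open) on this estimate. Compound 4 is estimated at 20000 nM with an expected range of 8000 nM to 40000 nM and a report of only a limit is likely.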

Compound 4, half-maximal inhibitory concentration: > 20000 nM
Compound 4: only a limit was reported (the forecaster's own chance of this, stated with the estimate: 65%); the middle value lies on the limit itself.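

In this assay, phenyl in place of furan-2-yl at this aromatic carbon of the shared core gives an at least 1.3-fold higher number from compound 2 to compound 4 (0.12 log units; that floor lies within the scatter). The steps to compound 4 from compound 3 and from compound 1 cannot be read, as each joins two limits, so neither the exchange of furan-3-yl for phenyl nor that of methylsulfanyl for methylamino has a size. With phenyl now tested alongside methylamino, compound 2 is the only compound with a number, and the other results share one limit: the limit of > 20000 nM in this assay, at which 3 of the 4 values shown sit.

Going by these compounds, whether any group at this carbon gives a value clear of that limit stays open, including a carboxylic acid or an aminomethyl group. On these data alone, the size of the methylsulfanyl to methylamino exchange with phenyl held in place also stays open.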